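The compounds below may be only part of what the source reports. "The series", "measured", "known", "first", "only" and "open" are said of these compounds alone.

Measured compounds in an in vitro functional assay on HEK285-7 cells for antagonist activity at prostaglandin D2 receptor 2 (Homo sapiens), read by BRET and beta-arrestin recruitment; on this read-out lower numbers stand for smaller maximal responses and higher numbers for larger maximal responses:
compound 1 `COc1cc(-c2nc(C(c3ccc(F)cc3)c3ccc(F)cc3)sc2CC(=O)O)ccn1`: 60%
compound 2 `O=C(O)Cc1sc(C(c2ccccc2)c2ccc(Cl)cc2)nc1-c1ccc(F)cc1`: 80%
compound 3 `O=C(O)Cc1sc(C2COc3ccccc3O2)nc1-c1ccc(Cl)cc1`: 50%

Three compounds share a core that carries an acetic acid group, and each was tested in this assay for the largest response it could reach. Compound 1 gives 60% and stands second highest of the three. Its nearest neighbour is compound 3, which gives 50%; that gap lies within the usual scatter, so the two cannot be told apart on this read-out. The furthest is compound 2, which gives 80%, a higher number and a gap beyond the scatter.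

Compound 4 `O=C(O)Cc1sc(C(c2ccc(F)cc2)c2ccc(F)cc2)nc1-c1ccncc1` has not yet been measured. It differs from compound 1 in one place on the six-membered aromatic ring that holds one nitrogen: hydrogen in place of methoxy on an aromatic carbon. Cut one bond further out, the change reads 2-methoxypyridin-4-yl to pyridin-4-yl.

Among the compounds with values here, no measured pair here shows what this change does, so the expectation rests on compound 1 alone. The step is expected to be small: no change at the digits printed from compound 1 to compound 4 (within the scatter), none beyond the scatter in either direction. Compound 4 is therefore expected to give about 60%, within a range from 40% to 80%.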

Compound 4, largest response reached (reported as efficacy), in percent of the reference or control that the assay uses: 80%
For compound 4 the middle estimate is 20 percentage points below the measured one; the measured number falls inside the stated range.
By their numbers in this assay, from the lowest: compounds 3 and 1 (each within the scatter of the next); then compounds 2 and 4 (each within the scatter of the next).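

In this assay, within the data shown here, replacing methoxy with hydrogen on the aromatic carbon next to the ring nitrogen gives a number 20 percentage points higher from compound 1 to compound 4 (beyond the scatter), the first direct reading of what this change does. The earlier compounds shown here differed from one another in more than one place, so they could not isolate this position. This pair shows that the position matters on this read-out: with the rest of the molecule unchanged, exchanging a group of 2 heavy atoms for a single hydrogen atom is enough to give a difference larger than the usual scatter. No measurement available here accounts for that difference.

Going by these compounds, with only methoxy and hydrogen to compare, it remains open whether a different group at this position, such as an amine, a chlorine atom or a longer ethoxy chain, would give a response nearer to that of compound 1 or compound 4. This single pair also cannot show whether the same exchange would produce a similar step if the groups elsewhere on the shared core were different.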